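The source may hold more compounds than are shown below. What is called first, only, known or untested is meant among the compounds shown, and "the series" means these compounds.

Measured compounds:
- compound 1, `CCOc1ccc(NC(=O)c2cccc(/C=C3\CC(=O)N(Cc4ccccc4)C3=O)c2)cc1`: in an ADME assay on HCT-116 cells (Homo sapiens) for cytotoxicity, read by MTT assay, with a stated time of 72 h (on this read-out lower numbers stand for stronger inhibition and higher numbers for weaker inhibition), compound 1 gives 41700 nM
- compound 2, `CCOc1ccc(NC(=O)c2cccc(/C=C3\CC(=O)N(c4ccccc4)C3=O)c2)cc1`: compound 2 gives 84800 nM
- compound 3, `Cc1ccc(NC(=O)c2cccc(/C=C3\CC(=O)N(c4ccccc4)C3=O)c2)cc1C`: compound 3 reaches only a limit of the assay, > 100000 nM

Compound 1 has the lowest of the two numbers measured; compound 2 sits a 2.0-fold higher number from compound 1 to compound 2 (0.31 log units; beyond the scatter) away, a change of phenyl in place of benzyl on an amide-type nitrogen in a ring. From compound 2 to compound 3 the change of 3,4-dimethylphenyl in place of 4-ethoxyphenyl on an amide-type nitrogen gives an at least 1.1-fold higher number from compound 2 to compound 3 (0.07 log units; that floor lies within the scatter), and compound 3 stands at the limit described by the limit of > 100000 nM in this assay, at which 1 of the 3 values shown sits.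

The next compound, compound 4, `CCCCNC(=O)c1cccc(/C=C2\CC(=O)N(Cc3ccccc3)C2=O)c1`, differs from compound 1 by butyl in place of 4-ethoxyphenyl on an amide-type nitrogen. Neither measured step covers this change: one alters the ring nitrogen, the other swaps one aryl group for another on the same amide nitrogen, and that swap stayed within the scatter. The step to compound 4 replaces the aryl group by a short chain, which none of the three compounds shows, so the expectation leans on the weak numbers of the whole set. Compound 4 is expected to land near compound 1 or somewhat higher, with a chance of reaching the limit of the assay. The estimate for compound 4 is 60000 nM, between 25000 nM and 150000 nM, meaning a step of a 1.4-fold higher number from compound 1 to compound 4 (0.16 log units; within the scatter).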

Compound 4, half-maximal inhibitory concentration: 95100 nM
The estimate for compound 4 lay 1.6-fold (0.20 log units) below the measured number; the measured number falls inside the stated range.
By their numbers in this assay, from the lowest: compound 1; then compounds 2 and 4 (each within the scatter of the next). At a limit, above all of these: compound 3.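

In this assay, putting the open-chain butyl on this amide-type nitrogen in place of the ring-bearing 4-ethoxyphenyl gives a 2.3-fold higher number from compound 1 to compound 4 (0.36 log units; beyond the scatter), so the read-out does respond to a change at this position, though only modestly. The ring on this nitrogen is therefore not needed for a measurable effect, since compound 4 still gives a number, 95100 nM, and not a limit of the assay. That number lies close to the top of what this assay can report, so there is little room left to see any further loss here: the limit of > 100000 nM in this assay, at which 1 of the 4 values shown sits.

This single step removes the ring and the oxygen and also shortens the group, and the compounds shown cannot say which of these differences matters. Going by these compounds, an unsubstituted phenyl, a longer chain such as hexyl, or a butyl chain ending in an amine or a carboxylic acid on this nitrogen would help to pull those differences apart, and it remains open whether any of them would give a lower number than compound 1.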